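A few compounds are considered here, and "the series" means these few. Any claim that something is new, unique, unknown or untested is made for them only; others in the source may bear on it.

Measured so far:
Compound 1, `O=C(c1cncc(N2CC3CC(C2)N3)c1)N1CCCc2ccccc21` — in an assay on cells for displacement of a labelled ligand from Neuronal acetylcholine receptor; alpha3/beta4 (Homo sapiens) (a lower number here means a stronger inhibitor, a higher number a weaker inhibitor), compound 1 gives 62 nM
Compound 2, `O=C(Nc1ccccc1F)c1cncc(N2CC3CC(C2)N3)c1` — in this assay compound 2 gives 102 nM

Compound 2 has the higher of the two numbers, yet its gap to compound 1 lies within the usual scatter of repeated measurements, so the two cannot be told apart on these data. Compound 3, `O=C(NCc1ccccc1)c1cncc(N2CC3CC(C2)N3)c1`, shares the whole core of compound 2 and differs only in one place: benzyl in place of 2-fluorophenyl on an amide-type nitrogen. For the measured compounds named here, no directly comparable pair has been measured, so the size of this step is unknown. A group of the same size enters where the old one left, and nothing in the two measured values points to a large effect, so a step of at most modest size is expected, a 1.5-fold higher number from compound 2 to compound 3 (0.17 log units; within the scatter), leaning toward a somewhat higher number. Compound 3 is therefore estimated at 150 nM, with a range from 50 nM to 450 nM.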

Compound 3, inhibition constant: 1600 nM
Beside the measured number, compound 3's estimate is 11-fold (1.03 log units) below it, and the stated range ends below it.
By their numbers in this assay, from the lowest: compounds 1 and 2 (each within the scatter of the next); then compound 3.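

In this assay, the group on the amide-type nitrogen turns out to matter greatly: benzyl in place of 2-fluorophenyl gives a 16-fold higher number from compound 2 to compound 3 (1.20 log units; beyond the scatter), a large step beyond the scatter. For the compounds shown here, both groups have the same number of heavy atoms and one six-membered aromatic ring, so this match in size and ring type does not make them interchangeable here, something the earlier compounds, with no measured step at this position, could not show. Nothing measured here accounts for the step.

Going by these compounds, it remains open whether the loss of the fluorine or the carbon linking the ring to the nitrogen in benzyl counts for more, a question that a plain phenyl group on the same nitrogen could help settle. On these data alone, how a longer chain, such as 2-phenylethyl, would behave here also remains open.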